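Exchanging one aryl group on a compound at the limit

The source may hold more compounds than are shown below. What is called first, only, known or untested is meant among the compounds shown, and "the series" means these compounds.

Measured in a functional assay on DU-145 cells (Homo sapiens) for inhibition, read by trypan blue exclusion, with a stated time of 96 h; on this read-out lower numbers stand for stronger inhibition of growth and higher numbers for weaker inhibition of growth:
Compound 1 `O=C(O)c1ccc(/C=C(/SCc2ccc(Cl)cc2)C(=O)c2ccc(C(=O)O)cc2)cc1`: > 100000 nM (a limit)
Compound 2 `Cc1ccc(/C=C(\C(=O)c2ccc([N+](=O)[O-])cc2)S(=O)(=O)Cc2ccc(Cl)cc2)s1`: 25000 nM

In this assay compound 1 gives > 100000 nM, which is a limit of the assay and not a number. Compound 3 `O=C(O)c1ccc(C(=O)/C(=C\c2ccc(Br)c([N+](=O)[O-])c2)SCc2ccc(Cl)cc2)cc1` has not yet been measured. It differs from compound 1 in one place, on a double-bonded chain carbon bound to a double-bonded chain carbon: 4-bromo-3-nitrophenyl in place of 4-carboxyphenyl on a double-bonded chain carbon bound to a double-bonded chain carbon. For the measured compounds named here, no measured step shows what this exchange does, so the expectation is uncertain. It rests on compound 2, which gives 25000 nM in this assay and carries no 4-carboxyphenyl group. The expected change, towards stronger inhibition of growth, is estimated as an at least 5.0-fold lower number from compound 1 to compound 3 (0.69 log units; beyond the scatter). Compound 3 is expected at 20000 nM, with an estimated range of 4000 nM to 100000 nM.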

Compound 3, concentration for 50% growth inhibition: < 1000 nM
Compound 3 gave a limit, no number; the forecaster's own chance of this, stated with the estimate: 25%; middle value at least 20-fold (1.30 log units) away from the limit.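

In this assay, placing 4-bromo-3-nitrophenyl in place of 4-carboxyphenyl on a double-bonded chain carbon bound to a double-bonded chain carbon gives an at least 100-fold lower number from compound 1 to compound 3 (2.00 log units; beyond the scatter), the first step read at this position, and it shows that growth inhibition responds strongly to the aryl group carried there. Compound 3 still carries a 4-carboxyphenyl group elsewhere on the core, so the presence of that group alone does not keep a compound of this series at the upper limit. The value of compound 3 is itself a limit and not a number, which leaves the full size of the step unfixed: the limit of < 1000 nM in this assay, at which 1 of the 3 values shown sits.

Bromine and the nitro group enter together in this one exchange, and the compounds shown leave open which of them accounts for the change. Also open, from the compounds shown here alone, is how an amine on this aryl ring, or a plain phenyl group at this position, would read.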